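Replacing the 2-cyanobenzyl group on the ring amine nitrogen

The source may report more compounds than this note shows. Statements on the series, on what has been measured and on what is new or still open speak of the compounds shown alone.

Compound 1 `N#Cc1ccccc1CN1CCc2c(sc(NC(=O)c3ccccc3Cl)c2C(N)=O)C1` has been tested in a functional assay on HeLa cells (Homo sapiens) for antiproliferative activity, with a stated time of 24 h; on this read-out lower numbers stand for stronger inhibition and higher numbers for weaker inhibition. In this assay compound 1 gives > 50000 nM, which is a limit of the assay and not a number. Compound 2 `NC(=O)c1c(NC(=O)c2ccc(C(F)(F)F)cc2)sc2c1CCN(Cc1ccc(Cl)cc1Cl)C2` likewise gives only the limit > 50000 nM. Compound 3 `Cc1ccc(C(=O)Nc2sc3c(c2C(N)=O)CCN(Cc2ccc(Cl)cc2Cl)C3)cc1` also stops at the limit > 50000 nM. Within the data shown here, the single recorded step, a step that the two limits leave unreadable from compound 2 to compound 3, is unreadable, as the limit of > 50000 nM in this assay, at which 3 of the 3 values shown sit, states, and it concerns a different part of the core. Compound 4 `NC(=O)c1c(NC(=O)c2ccccc2Cl)sc2c1CCN(C(=S)Nc1ccccc1)C2` remains unmeasured; it differs from compound 1 by a group of 9 heavy atoms (7 carbon, 1 nitrogen, 1 sulfur; one six-membered aromatic ring of carbon only) in place of a group of 9 heavy atoms (8 carbon, 1 nitrogen; one six-membered aromatic ring of carbon only), on an amine nitrogen in a ring. Among the measured compounds shown here, no measured step bears on this change, so no direction beyond the scatter can be read. Due to the limit of > 50000 nM in this assay, at which 3 of the 3 values shown sit, compound 4 is expected to give about 50000 nM, estimated between 15000 nM and 150000 nM. That estimate means a number no higher from compound 1 to compound 4 (the limit leaves the size open).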

Compound 4, half-maximal inhibitory concentration: 46700 nM
Compound 4: middle estimate off by 1.1-fold (0.03 log units), on the high side; low and high end bracket the measured number.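

Swapping 2-cyanobenzyl for the sulfur-containing group on an amine nitrogen in a ring gives an at least 1.0-fold lower number from compound 1 to compound 4 (0.02 log units; that floor lies within the scatter). Among these compounds, compound 4 thus carries the only value shown that is a number rather than a limit, and it shows that this position tolerates the new group without any readable gain. How far the step reaches stays open due to the assay limit: the limit of > 50000 nM in this assay, at which 3 of the 4 values shown sit.

Still open, going by these compounds, is whether a urea, with oxygen in place of the sulfur, or an acetyl group on the same nitrogen would move the number beyond the scatter.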